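The source may report more compounds than this note shows. Statements on the series, on what has been measured and on what is new or still open speak of the compounds shown alone.

In a functional assay on MDA-MB-435S cells (Homo sapiens) for cytotoxicity, read by MTT assay (on this read-out higher numbers stand for weaker inhibition and lower numbers for stronger inhibition), compound 1 (`COc1ccc(-c2oc3c(CC=C(C)C)c(OC(C)C(=O)O)cc(O)c3c(=O)c2O)cc1`) gives 5700 nM. Compound 2 (`COc1ccc(-c2oc3c(CC=C(C)C)c(OCCOC(=O)CCCC(=O)O)cc(O)c3c(=O)c2OCCOC(=O)CCCC(=O)O)cc1`) gives 6300 nM, and these two numbers lie within the scatter of each other. Compound 3 (`COc1ccc(-c2oc3c(CC=C(C)C)c(OC(C)C(=O)O)cc(O)c3c(=O)c2OC(C)C(=O)O)cc1`) has two entries in this assay, > 100000 nM; 26700 nM (2 entries). The first of these entries is a limit of the assay, not a number.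

Compound 4 (`CCOC(=O)COc1cc(O)c2c(=O)c(O)c(-c3ccc(OC)cc3)oc2c1CC=C(C)C`) has not yet been measured. It carries (ethoxycarbonyl)methyl in place of the 1-carboxyethyl of compound 1, on an oxygen on an aromatic ring: (ethoxycarbonyl)methyl in place of 1-carboxyethyl on an oxygen on an aromatic ring. Within the data shown here, no measured pair differs in one place only, so this step has no direct guide. Compound 2, with chains of its own, stays at 6300 nM, so no change beyond the scatter is expected in this assay. The expected step, a 1.1-fold higher number from compound 1 to compound 4 (0.02 log units; within the scatter), is therefore small. Compound 3 goes against this picture, so the range is kept wide on the upper side. For compound 4 the estimated value is 6000 nM, with an expected range of 2000 nM to 20000 nM.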

Compound 4, half-maximal inhibitory concentration: 5300 nM
Estimate against measurement, compound 4: 1.1-fold (0.05 log units) above; the range from low to high includes it.
By their numbers in this assay, from the lowest: compounds 4, 1 and 2 (each within the scatter of the next).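

Among these compounds, on an oxygen on an aromatic ring, (ethoxycarbonyl)methyl in place of 1-carboxyethyl gives, in this assay, a 1.1-fold lower number from compound 1 to compound 4 (0.03 log units; within the scatter), the only step that differs in one place. It shows that at this position, the change from 1-carboxyethoxy to (ethoxycarbonyl)methoxy, which removes the hydrogen-bond donor of the group that leaves, does not move the number beyond the scatter. No measurement shown here gives a reason why the two groups read alike.

This one step alters the end of the chain and its carbon skeleton together, so the share of each cannot be told apart. Going by these compounds, whether an amine, an amide or a longer chain on this same oxygen would also leave the number within the scatter stays open.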